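A few compounds are considered here, and "the series" means these few. Any claim that something is new, unique, unknown or untested is made for them only; others in the source may bear on it.

Measured so far in a functional assay on SMMC-7721 cells (Homo sapiens) for cytotoxicity, read by MTT assay, with a stated time of 72 h; a lower number here means a stronger inhibitor, a higher number a weaker inhibitor:
compound 1, `CCNC(=O)N1CCN(C(=S)SCc2cn(Cc3ccc(F)cc3)nn2)CC1`: 44400 nM
compound 2, `CC(C)NC(=O)N1CCN(C(=S)SCc2cn(Cc3ccc(F)cc3)nn2)CC1`: 5970 nM

Among the measured compounds shown here, compound 2 gives the lowest of the two numbers in this assay; its nearest neighbour is compound 1, and the single measured step, a 7.4-fold lower number from compound 1 to compound 2 (0.87 log units; beyond the scatter), is a methyl in place of hydrogen on a saturated chain carbon bound to an amide-type nitrogen, on the urea side of the shared core.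

Compound 3, `Cc1ccc(Cn2cc(CSC(=S)N3CCN(C(=O)NC(C)C)CC3)nn2)cc1`, differs from compound 2 by methyl in place of fluoro on an aromatic carbon. For the measured compounds named here, no measured step touches this aromatic carbon; the one known step sits on the opposite end of the core, so it offers no guide to the change here. With nothing bearing on it, the expectation for this assay is a step of a 1.0-fold higher number from compound 2 to compound 3 (0.00 log units; within the scatter), not expected to go beyond the scatter. Compound 3 is therefore estimated at 6000 nM, with a range from 2000 nM to 20000 nM.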

Compound 3, half-maximal inhibitory concentration: > 128000 nM
Compound 3: a limit, no number (the forecaster's own chance of this, stated with the estimate: 5%); middle value at least 21-fold (1.32 log units) away from the limit.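

In this assay compound 3 gives > 128000 nM, which is a limit of the assay and not a number. The exchange of 4-fluorophenyl for 4-methylphenyl gives an at least 21-fold higher number from compound 2 to compound 3 (1.33 log units; beyond the scatter). This shows that the aromatic carbon para to a large group is not a silent position in this series: an exchange of one heavy atom there moves the read-out beyond the scatter, so the urea side of the shared core is not the only place where a small change counts.

With only fluoro and methyl shown at this position, it stays open whether fluoro favours the read-out or methyl disfavours it, and a hydrogen, chloro or methoxy group there would separate the two. As far as these compounds go, whether the methyl exchange has the same effect with the shorter urea chain of compound 1 also stays open.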